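Chloro on the pyrimidinone phenyl of compound 2

A few compounds are considered here, and "the series" means these few. Any claim that something is new, unique, unknown or untested is made for them only; others in the source may bear on it.

Three members of the series have numbers in a functional assay on MDA-MB-231 cells (Homo sapiens) for antiproliferative activity, with a stated time of 72 h; on this read-out lower numbers stand for stronger inhibition and higher numbers for weaker inhibition. Compound 1 `Cn1c(N2N=C(c3ccccc3)CC2c2ccc(F)cc2)nc(-c2ccccc2)c(C#N)c1=O` gives 11800 nM, compound 2 `Cc1ccc(C2=NN(c3nc(-c4ccccc4)c(C#N)c(=O)n3C)C(c3ccc(F)cc3)C2)cc1` gives 5100 nM, and compound 3 `Cn1c(N2N=C(c3ccccc3)CC2c2ccc(Cl)cc2)nc(-c2ccc(Cl)cc2)c(C#N)c1=O` gives 25100 nM. Compound 2 stands lowest of the three, with compound 1 nearest and compound 3 furthest; both gaps lie beyond the scatter. Within the data shown here, the one single-point step known is a 2.3-fold lower number from compound 1 to compound 2 (0.36 log units; beyond the scatter), a methyl in place of hydrogen on an aromatic carbon.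

Compound 4 `Cc1ccc(C2=NN(c3nc(-c4ccc(Cl)cc4)c(C#N)c(=O)n3C)C(c3ccc(F)cc3)C2)cc1` is compound 2 with chloro in place of hydrogen on an aromatic carbon; cut one bond further out, the difference reads phenyl to 4-chlorophenyl. Among the measured compounds shown here, no measured step bears on this change directly. Compound 3 carries a chloro on the same ring, but it differs from compound 1 in two places, so its higher number against compound 1 can only hint, not quantify. The measured methyl step is a different group on a different ring and does not transfer.

Taken together, compound 4 is expected to sit near compound 2, with at most a modest drift toward weaker inhibition, an expected 1.5-fold higher number from compound 2 to compound 4 (0.17 log units; within the scatter). The estimate for compound 4 in this assay is 7500 nM, within a range from 3000 nM to 20000 nM.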

Compound 4, half-maximal inhibitory concentration: 19300 nM
For compound 4 the middle estimate is 2.6-fold (0.41 log units) below the measured one; measured number inside the range.
By their numbers in this assay, from the lowest: compound 2; then compounds 1, 4 and 3 (each within the scatter of the next, the first and the last beyond it).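

Phenyl to 4-chlorophenyl in this assay comes out as a 3.8-fold higher number from compound 2 to compound 4 (0.58 log units; beyond the scatter), which gives this position its first directly measured step: one chlorine entering para to a large group moves the number toward weaker inhibition, beyond the scatter. Among these compounds, until now the only compound with a chloro on this ring was compound 3, which differs from compound 1 in two places and so could not isolate the change; the new pair differs in this one place alone. The step also runs in the opposite direction to a 2.3-fold lower number from compound 1 to compound 2 (0.36 log units; beyond the scatter), so the two single-atom-sized additions shown, methyl and chloro, sitting on different rings, do not move the number the same way.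

No measured information at hand accounts for the size or direction of this step. The compounds shown leave open how a methoxy group, an amine or a carboxylic acid in the same place would compare with hydrogen and chloro, and whether the chloro step holds on the methyl-free background of compound 1.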